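Dropping one pyrimidine methyl from a coumarin sulfonamide

The compounds below may be only part of what the source reports. "The series", "measured", "known", "first", "only" and "open" are said of these compounds alone.

Measured so far:
compound 1 `Cc1ccnc(NS(=O)(=O)c2ccc(/N=C/c3c(Cl)c4ccccc4oc3=O)cc2)n1` — 230 nM
compound 2 `Cc1ccc2oc(=O)c(/C=N/c3ccc(S(=O)(=O)Nc4nc(C)cc(C)n4)cc3)c(Cl)c2c1` — 300 nM

In a functional assay on B16-F10 cells (Mus musculus) for cytotoxicity, read by CCK-8 assay, with a stated time of 48 h (on this read-out lower numbers stand for stronger inhibition and higher numbers for weaker inhibition), compound 1 gives 230 nM. In this assay compound 2 gives 300 nM. Among the compounds with values here, these two compounds differ in more than one place, so no single step connects them; their two numbers lie within the scatter of each other, and compound 2 therefore stands alongside compound 1 rather than apart from it.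

Compound 3 `Cc1ccc2oc(=O)c(/C=N/c3ccc(S(=O)(=O)Nc4nccc(C)n4)cc3)c(Cl)c2c1` has not yet been measured. It differs from compound 2 by a hydrogen in place of methyl on an aromatic carbon. Because compound 1, which also carries a 4-methylpyrimidin-2-yl group, gives 230 nM, no step beyond the scatter is expected here, in either direction. The expected step is no change at the digits printed from compound 2 to compound 3 (within the scatter). Compound 3 is estimated at 300 nM, with a range from 150 nM to 600 nM.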

Compound 3, half-maximal inhibitory concentration: 270 nM
Compound 3: middle estimate off by 1.1-fold (0.05 log units), on the high side; the range from low to high includes it.
By their numbers in this assay, from the lowest: compounds 1, 3 and 2 (each within the scatter of the next).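

In this assay, taking one methyl off the 4,6-dimethylpyrimidin-2-yl group to leave 4-methylpyrimidin-2-yl gives a 1.1-fold lower number from compound 2 to compound 3 (0.05 log units; within the scatter), so at this position, opposite the ring nitrogen, hydrogen and methyl read alike in this series. Compound 3 also supplies the first single-change link to compound 1: methyl in place of hydrogen on an aromatic carbon of the shared core gives a 1.2-fold higher number from compound 1 to compound 3 (0.07 log units; within the scatter), so that methyl likewise leaves the number within the scatter. Nothing measured here bears on what lies behind these two results.

Still open, as far as these compounds go, is whether this pyrimidine position accepts a group other than methyl, such as a methoxy group, an amine or a carboxylic acid. Equally open, from the compounds shown here alone, is how a larger group, such as a tert-butyl group, would read at the methyl position on the core.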